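This account rests on a few compounds, and the source may have more. Where it says the series, first, only, none or still open, it means among the compounds named here.

Measured in an assay for positive allosteric modulation of metabotropic glutamate receptor 3 (Rattus norvegicus); a higher number here means that more compound is needed for the effect, a lower number that less compound is needed:
Compound 1, `COc1cc(C(=O)O)ccc1OC[C@H](C)COc1ccc(C(=O)CC(C)(C)C)c(O)c1C`, gives 512 nM.
Compound 2, `Cc1c(OC[C@@H](C)COc2ccc(C(=O)O)cc2Cl)ccc(C(=O)CC(C)(C)C)c1O`, gives 1650 nM.
Compound 3, `Cc1c(OC[C@@H](C)COc2ccc(C(=O)O)c(Cl)c2)ccc(C(=O)CC(C)(C)C)c1O`, gives 860 nM.

Compounds 2 and 3 share the same atoms joined differently: 4-carboxy-3-chlorophenyl in place of 4-carboxy-2-chlorophenyl on an oxygen on a saturated carbon. That rearrangement gave a 1.9-fold lower number from compound 2 to compound 3 (0.28 log units; within the scatter). Compounds 2 and 1 differ by methoxy in place of chloro on an aromatic carbon, and that exchange gave a 3.2-fold lower number from compound 2 to compound 1 (0.51 log units; beyond the scatter).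

Compound 4, `COc1cc(OC[C@H](C)COc2ccc(C(=O)CC(C)(C)C)c(O)c2C)ccc1C(=O)O`, has not yet been measured in this assay. It differs from compound 3 by methoxy in place of chloro on an aromatic carbon. This is the same kind of change as from compound 2 to compound 1, but not the same: there the methoxy entered ortho to a large group and meta to a carboxy group, whereas here it enters ortho to a carboxy group and meta to a large group. Because a 3.2-fold lower number from compound 2 to compound 1 (0.51 log units; beyond the scatter) was modest and beyond the scatter, a step of roughly similar direction is expected, a 2.2-fold lower number from compound 3 to compound 4 (0.33 log units; beyond the scatter), though the differing surroundings make it less certain. Compound 4 is therefore estimated at 400 nM, with a range from 150 nM to 1200 nM.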

Compound 4, half-maximal effective concentration: 1460 nM
Compound 4: the middle estimate sits 3.7-fold (0.56 log units) below what was measured, and the stated range ends below it.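

In this assay, methoxy in place of chloro gave a 1.7-fold higher number from compound 3 to compound 4 (0.23 log units; within the scatter), so the clear drop seen with the same exchange on the other core did not recur. The exchange therefore cannot be carried from one core to the other in this series with its size and direction intact: the same change on two cores in this assay, a 3.2-fold lower number (0.51 log units; beyond the scatter) from compound 2 to compound 1 and a 1.7-fold higher number (0.23 log units; within the scatter) from compound 3 to compound 4, 5.5-fold (0.74 log units) apart, beyond the scatter of two such steps. This shows that the two cores respond differently, with the methoxy here ortho to a carboxy group, but two cases do not show what causes the difference or how a further core would respond.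

The compounds shown leave open how a fluoro or a methyl group would fare at these places. They also leave open whether an amide could stand in for the carboxy group.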